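The source may report more compounds than this note shows. Statements on the series, on what has been measured and on what is new or still open speak of the compounds shown alone.

Of the compounds shown here, three carrying a shared core have been measured in a functional assay on A549 cells (Homo sapiens) for inhibition, read by MTT assay, with a stated time of 72 h, tested at 20 uM; on this read-out lower numbers stand for less inhibition and higher numbers for more inhibition at the one concentration tested (going by the name of the read-out). Compound 1, `c1cc(N2CCCC2)nc(Nc2ccc(Oc3ncnc4ccsc34)cc2)n1`, gives 23.2%. Compound 3, `c1cc(N2CCCCC2)nc(Nc2ccc(Oc3ncnc4sccc34)cc2)n1`, gives 64.8%. Compound 2, `CN(c1ccc(Oc2ncnc3sccc23)cc1)c1nccc(N2CCCCC2)n1`, gives 51.9% and stands second highest of the three, with compound 3 nearest and compound 1 furthest from it. Among the measured compounds shown here, the one step recorded between compounds differing in a single place runs a number 12.9 percentage points higher from compound 2 to compound 3 (beyond the scatter); it does not touch the change considered here.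

Compound 4, `CN(c1ccc(Oc2ncnc3sccc23)cc1)c1nccc(N2CCCC2)n1`, differs from compound 2 by pyrrolidin-1-yl in place of piperidin-1-yl on an aromatic carbon. For the measured compounds named here, no measured step covers this exchange directly. What the data show is that compound 1, which bears pyrrolidin-1-yl, gives 23.2%, whereas compound 3, which bears piperidin-1-yl, gives 64.8%, the two otherwise alike. Going by the values given here, this comparison suggests that replacing the six-membered ring with the five-membered one lowers inhibition in this assay by a sizable amount, though only one such pair exists and its step is not recorded.

On that basis compound 4 is expected to fall below compound 2, with an estimated step of a number 23.9 percentage points lower from compound 2 to compound 4 (beyond the scatter). The estimate for compound 4 is 28%, in a range from 10% to 48%.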

Compound 4, a percentage reported as inhibition, at one concentration (the size of the read-out at that concentration, not a potency): 55.5%
Estimate against measurement, compound 4: 27.5 percentage points below; measured number outside the range, above it.
By their numbers in this assay, from the lowest: compound 1; then compounds 2, 4 and 3 (each within the scatter of the next, the first and the last beyond it).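

In this assay, the direct exchange on an aromatic carbon of the six-membered aromatic ring with 2 nitrogen gives a number 3.6 percentage points higher from compound 2 to compound 4 (within the scatter), so with the rest of the molecule held fixed, this read-out does not separate pyrrolidin-1-yl from piperidin-1-yl at this position. The low number of compound 1, at 23.2%, therefore cannot be taken as the effect of the five-membered ring: the core of compound 1 is not the core of compound 3, so that pair differs in more than one place and its gap belongs to neither change alone. The data shown offer no measurement that would explain why the two rings read alike here.

As far as these compounds go, what remains open is whether the same holds with a hydrogen rather than a methyl on the linking nitrogen, since compound 3 has a piperidin-1-yl partner of that kind only on the core of compound 2 and no pyrrolidin-1-yl partner. From the compounds shown here alone, it is also open whether a morpholin-4-yl ring or an open-chain dimethylamino group at this position would read alike in this assay.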